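Varying the Aryl Group on the Ring Amine Nitrogen

The source may hold more compounds than are shown below. What is called first, only, known or untested is meant among the compounds shown, and "the series" means these compounds.

Measured in a functional assay on DU-145 cells (Homo sapiens) for cytotoxicity, read by sulforhodamine B assay, with a stated time of 48 h (a lower number here means that less compound is tolerated, a higher number that more compound is tolerated), so far:
Compound 1 `N#Cc1ccc(Nc2nc(Oc3ccnc4ccccc34)nc(N3CCN(c4ccccc4F)CC3)n2)cc1C(F)(F)F`: > 100000 nM
Compound 2 `N#Cc1ccc(Nc2nc(Oc3ccnc4ccccc34)nc(N3CCN(c4cccc(Cl)c4Cl)CC3)n2)cc1C(F)(F)F`: > 100000 nM
Compound 3 `N#Cc1ccc(Nc2nc(Oc3ccnc4ccccc34)nc(N3CCN(c4cccc(C(F)(F)F)c4)CC3)n2)cc1C(F)(F)F`: > 100000 nM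

Compound 1 gives only a limit in this assay, > 100000 nM. Compound 2 likewise gives a limit, > 100000 nM. Compound 3 also gives a limit, > 100000 nM. Because all three values sit at the same limit (the limit of > 100000 nM in this assay, at which 3 of the 3 values shown sit), the steps a step that the two limits leave unreadable from compound 1 to compound 2, a step that the two limits leave unreadable from compound 1 to compound 3 and a step that the two limits leave unreadable from compound 2 to compound 3 cannot be read in size. Compound 4 `N#Cc1ccc(Nc2nc(Oc3ccnc4ccccc34)nc(N3CCN(c4ccc(F)cc4)CC3)n2)cc1C(F)(F)F` differs from compound 3 thus: 4-fluorophenyl in place of 3-(trifluoromethyl)phenyl on an amine nitrogen in a ring. Each earlier change at this position left the limit unchanged, so no step beyond the scatter is expected from compound 3 to compound 4, a number no higher from compound 3 to compound 4 (the limit leaves the size open). Compound 4 is therefore expected to give about 100000 nM, between 50000 nM and 300000 nM, most likely again as a limit.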

Compound 4, concentration lethal to 50% of the cells: > 100000 nM
Compound 4 gave a limit, no number (the forecaster's own chance of this, stated with the estimate: 85%); the middle value lies on the limit itself.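

Compound 4 also gives only a limit, > 100000 nM. Its steps from compound 1, compound 2 and compound 3 therefore cannot be read in size: the limit of > 100000 nM in this assay, at which 4 of the 4 values shown sit. The compounds shown leave open whether any aryl group at this position would give a measurable number in this assay.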